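This account rests on a few compounds, and the source may have more. Where it says the series, first, only, none or still open, it means among the compounds named here.

Measured so far in a physicochemical assay for solubility; a higher number here means a more soluble compound, a lower number a less soluble compound:
- compound 1 `CC(C)C[C@@H](N)C(=O)OC[C@H]1O[C@@H](n2cnc3c(N)ncnc32)[C@@H](O)[C@@H]1O`: > 10000 ug/mL
- compound 2 `Nc1ncnc2c1ncn2[C@@H]1O[C@H](COC(=O)C[C@@H](N)C(=O)O)[C@@H](O)[C@@H]1O`: > 10000 ug/mL

Compound 2 stands at > 10000 ug/mL, which is a limit and not a number. The same holds for compound 1, so the limit of > 10000 ug/mL in this assay, at which 2 of the 2 values shown sit, describes all that has been measured. Compound 3 `CC(C)[C@H](N)C(=O)OC[C@H]1O[C@@H](n2cnc3c(N)ncnc32)[C@@H](O)[C@@H]1O` differs from compound 2 by 1-amino-2-methylpropyl in place of 2-amino-2-carboxyethyl on a carbonyl carbon, with 1-amino-2-methylpropyl in place of 2-amino-2-carboxyethyl on a carbonyl carbon.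

Among the measured compounds shown here, only one measured step bears on this change, a step that the two limits leave unreadable from compound 1 to compound 2, and it gives no size to carry over. The expectation rests instead on compound 1, which carries 1-amino-3-methylbutyl at that place and stands at the limit of > 10000 ug/mL. For the measured compounds named here, no step of known size or direction is therefore expected in this assay, and the assay will probably report a limit again. The expected step is a step that the limit leaves unreadable from compound 2 to compound 3. For compound 3 the estimate is 12000 ug/mL, with an expected range from 5000 ug/mL to 30000 ug/mL.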

Compound 3, solubility: > 10000 ug/mL
Compound 3: no number, only a limit; the forecaster's own chance of this, stated with the estimate: 80%; the middle value lies beyond the limit too.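

In this assay, among the compounds shown here, compound 3 gives > 10000 ug/mL, a limit and not a number, so no step from compound 1 or compound 2 to compound 3 can be read. The compounds shown leave open whether these three differ in solubility at all, with every value at: the limit of > 10000 ug/mL in this assay, at which 3 of the 3 values shown sit.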